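Saturated ring in place of the aryl group on compound 1

The compounds below may be only part of what the source reports. "The series", "measured", "known", "first", "only" and "open" are said of these compounds alone.

Values in an assay on CHO cells for displacement of a labelled ligand from Substance-P receptor (Homo sapiens); a lower number here means a stronger inhibitor, a higher number a weaker inhibitor:
compound 1 `C[C@@H](O[C@H]1CN2C(=O)C=C(c3ccc(CO)cc3)CC2[C@@H]1c1ccc(F)cc1)c1cc(C(F)(F)F)cc(C(F)(F)F)c1`: 0.39 nM
compound 2 `COc1cc(C2=CC(=O)N3C[C@H](O[C@H](C)c4cc(C(F)(F)F)cc(C(F)(F)F)c4)[C@@H](c4ccc(F)cc4)C3C2)ccn1`: 1.1 nM

Within the data shown here, compound 1 has the lower of the two numbers; the one step known is a 2.8-fold higher number from compound 1 to compound 2 (0.45 log units; beyond the scatter), an exchange of one six-membered aromatic ring for another. Compound 3 `C[C@@H](O[C@H]1CN2C(=O)C=C(C3CCOCC3)CC2[C@@H]1c1ccc(F)cc1)c1cc(C(F)(F)F)cc(C(F)(F)F)c1` differs from compound 1 by oxan-4-yl in place of 4-(hydroxymethyl)phenyl on a double-bonded ring carbon. That step bears only loosely here: the aromatic ring gives way to a non-aromatic one and the donor is lost, a larger change than the measured one. A modest weakening beyond the scatter is expected, a 3.3-fold higher number from compound 1 to compound 3 (0.52 log units; beyond the scatter). Compound 3 is estimated at 1.3 nM, within 0.4 nM to 4.5 nM.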

Compound 3, half-maximal inhibitory concentration: 0.09 nM
Compound 3: middle estimate off by 14-fold (1.16 log units), on the high side; the measured number lies below the stated range.
By their numbers in this assay, from the lowest: compound 3; then compound 1; then compound 2.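

In this assay, oxan-4-yl on the double-bonded ring carbon gives a lower number than either aromatic group (a 4.3-fold lower number from compound 1 to compound 3 (0.64 log units; beyond the scatter)) and (a 12-fold lower number from compound 2 to compound 3 (1.09 log units; beyond the scatter)). Among these compounds, neither an aromatic ring nor the hydrogen-bond donor of 4-(hydroxymethyl)phenyl is needed at this position for a sub-nanomolar-range number. Nothing available explains this gain.

As far as these compounds go, whether the ring oxygen of oxan-4-yl contributes remains open, and cyclohexyl would test that directly. Also open, from the compounds shown here alone, is whether piperidin-4-yl, which carries a ring amine, keeps the number this low.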